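Dropping the methoxy from compound 2

This account rests on a few compounds, and the source may have more. Where it says the series, first, only, none or still open, it means among the compounds named here.

Of the compounds shown here, three of the shared core have been measured in a functional assay on MCF7 cells (Homo sapiens) for cytotoxicity, read by MTT assay, with a stated time of 72 h; a lower number here means a stronger inhibitor, a higher number a weaker inhibitor. Compound 1 `COc1cc(C=C2C(=O)N(c3ccc(Cl)cc3)N(c3ccc(Cl)cc3)C2=O)cc(OC)c1OC` gives 16200 nM. Compound 3 `CC(=C1C(=O)N(c2ccc(Cl)cc2)N(c2ccc(Cl)cc2)C1=O)c1ccc(O)cc1` gives 76500 nM. Compound 2 `COc1ccc(C=C2C(=O)N(c3ccc(Cl)cc3)N(c3ccc(Cl)cc3)C2=O)cc1` returns only a limit, > 128000 nM. That limit, (the limit of > 128000 nM in this assay, at which 1 of the 3 values shown sits), is where compound 2 stands, with no number beneath it to anchor a step, so compound 2 sits at the weak end of the numbers shown. Compound 4 `O=C1C(=Cc2ccccc2)C(=O)N(c2ccc(Cl)cc2)N1c1ccc(Cl)cc1` is the next member; it differs from compound 2 by hydrogen in place of methoxy on an aromatic carbon. Among the compounds with values here, no measured pair in this set differs only at that place, so the size of the step is open. The step of an at least 1.1-fold lower number from compound 2 to compound 4 (0.06 log units; that floor lies within the scatter) is expected to be none beyond the scatter. Compound 4 is expected to give around 110000 nM, within 30000 nM to 400000 nM, and may again return only a limit.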

Compound 4, half-maximal inhibitory concentration: 20200 nM
The estimate for compound 4 lay 5.4-fold (0.74 log units) above the measured number; measured number below the stated range.
By their numbers in this assay, from the lowest: compounds 1 and 4 (each within the scatter of the next); then compound 3. At a limit, above all of these: compound 2.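

In this assay, within the data shown here, the change from 4-methoxyphenyl to phenyl gives an at least 6.3-fold lower number from compound 2 to compound 4 (0.80 log units; beyond the scatter), the first readable step at this place, and it lies beyond the scatter. On this core, methoxy para to a large group therefore goes with the weaker number, and hydrogen there gives the stronger one. Compound 2 is held only at a limit, so the step is a floor and its full size cannot be read: the limit of > 128000 nM in this assay, at which 1 of the 4 values shown sits.

The compounds shown leave open how an amine or a carboxylic acid at this place would compare with hydrogen and methoxy.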